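This account rests on a few compounds, and the source may have more. Where it says the series, first, only, none or still open, it means among the compounds named here.

Two compounds bear the same core and differ only in the amine that caps the propynyl chain. Compound 1 `CCN(CC)CC#Cc1ccnc2ccc(-c3cnc(OC)c(NS(=O)(=O)c4ccc(F)cc4F)c3)cc12` carries a diethylamino there, while compound 2 `COc1ncc(-c2ccc3nccc(C#CCN(C4CCCCC4)C4CCCCC4)c3c2)cc1NS(=O)(=O)c1ccc(F)cc1F` carries an amine bearing two cyclohexyl groups. In an assay on isolated protein for inhibition of phosphatidylinositol 4,5-bisphosphate 3-kinase catalytic subunit beta isoform (Homo sapiens), read by luminescence and ADP-Glo, with a stated time of 40 min, tested at 10 nM (on this read-out higher numbers stand for more inhibition at the one concentration tested (going by the name of the read-out) and lower numbers for less inhibition), compound 1 gives 21%, and in this assay compound 2 gives 13%; the gap between these two numbers is within the usual scatter of the measurement, so neither can be set apart from the other on this evidence.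

Compound 3 `COc1ncc(-c2ccc3nccc(C#CCN4CCC(C)CC4)c3c2)cc1NS(=O)(=O)c1ccc(F)cc1F` has not yet been measured. It differs from compound 1 in one place: 4-methylpiperidin-1-yl in place of diethylamino on a saturated chain carbon bound to a triple-bonded carbon.

Among the measured compounds shown here, no measured pair isolates this particular change, so the expectation rests on the two numbers above. Because compound 2 gives 13% with a quite different amine on the same chain, the step from compound 1 to compound 3 is expected to be small, a number 3 percentage points lower from compound 1 to compound 3 (within the scatter), a change that stays within the scatter. Compound 3 is therefore estimated at 18%, with a likely range from 5% to 33%.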

Compound 3, a percentage reported as inhibition, at one concentration (the size of the read-out at that concentration, not a potency): 5.8%
Compound 3: middle estimate off by 12.2 percentage points, on the high side; the range from low to high includes it.
By their numbers in this assay, from the lowest: compounds 3, 2 and 1 (each within the scatter of the next, the first and the last beyond it).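

In this assay, among the compounds shown here, putting 4-methylpiperidin-1-yl in place of diethylamino on a saturated chain carbon bound to a triple-bonded carbon gives a number 15.2 percentage points lower from compound 1 to compound 3 (beyond the scatter), the first step at this position that stands clear of the usual scatter. The amine at the end of the propynyl chain is therefore not a place where any change goes unnoticed, since here an open-chain amine with 5 heavy atoms gives way to a ring-bearing amine with 7 and the read-out responds, although this is a single step and not a trend. Nothing measured here explains why this swap lowers the number.

The compounds shown leave open whether the ring, the methyl group or simply the added carbon atoms account for the step, and a plain piperidin-1-yl, which keeps the ring and lacks the methyl, would begin to separate these. For the compounds shown here, a morpholin-4-yl or a pyrrolidin-1-yl at the same place would also show how far the result depends on the ring's atoms and size, while every number so far remains inhibition at one concentration and not a potency.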